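The source may report more compounds than this note shows. Statements on the series, on what has been measured and on what is new or still open speak of the compounds shown alone.

Measured so far:

compound 1 `COc1ccc(CN(C(=O)Nc2ccc(F)c(Cl)c2)n2cnnc2)cc1OC` — 30100 nM
compound 2 `CCCCCCCCCNC(=O)N(Cc1cc(OC)ccc1OC)n1cnnc1` — > 50000 nM

Within the data shown here, in a functional assay on MCF7 cells (Homo sapiens) for cytotoxicity, read by MTT assay, with a stated time of 48 h (on this read-out higher numbers stand for weaker inhibition and lower numbers for stronger inhibition), compound 1 gives 30100 nM, the only outright number among the two values shown. Compound 2 reaches only the limit of the assay, > 50000 nM, and that figure is a limit rather than a measured number, as noted in the limit of > 50000 nM in this assay, at which 1 of the 2 values shown sits. Among the measured compounds shown here, because the two compounds differ in more than one place, no single-point step between measured compounds is available, and what the pair shows is simply one weak number beside one limit.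

Compound 3 `CCc1ccc(NC(=O)N(Cc2ccc(OC)c(OC)c2)n2cnnc2)cc1` has not yet been measured. It departs from compound 1 by one change: 4-ethylphenyl in place of 3-chloro-4-fluorophenyl on an amide-type nitrogen, in words 4-ethylphenyl in place of 3-chloro-4-fluorophenyl on an amide-type nitrogen. For the measured compounds named here, no measured step on this assay bears on such a swap, so the expected size of the step from compound 1 to compound 3 is set at a 1.3-fold higher number from compound 1 to compound 3 (0.10 log units; within the scatter), that is a shift within the usual scatter, with no clear direction beyond it. On that basis compound 3 is estimated at 38000 nM, with a range from 12000 nM to 120000 nM, and a real chance that only a limit is reported.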

Compound 3, half-maximal inhibitory concentration: > 50000 nM
Compound 3: only a limit was reported; the forecaster's own chance of this, stated with the estimate: 35%; middle value at least 1.3-fold (0.11 log units) away from the limit.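

In this assay, among these compounds, placing 4-ethylphenyl in place of 3-chloro-4-fluorophenyl on an amide-type nitrogen gives the only step available at this position, and it is a floor rather than a measured size: an at least 1.6-fold higher number from compound 1 to compound 3 (0.22 log units; that floor lies within the scatter). Compound 3 gives > 50000 nM, which is a limit and not a number. The change therefore brings no stronger read-out, but a real loss cannot be claimed either, and a measured number at this position is still seen only for compound 1, in a series where limits now predominate: the limit of > 50000 nM in this assay, at which 2 of the 3 values shown sit.

From the compounds shown here alone, how far compound 3 lies past its limit remains open, and with it whether the swap from 3-chloro-4-fluorophenyl to 4-ethylphenyl has any effect beyond the usual scatter. Also open, going by these compounds, is whether any other group on this amide-type nitrogen, such as a phenyl ring carrying an amine or a carboxylic acid, would give a clearly lower number than compound 1 in this assay.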